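Extending the Oxygen Substituent from Methyl to Phenyl

This account rests on a few compounds, and the source may have more. Where it says the series, first, only, none or still open, it means among the compounds named here.

Measured compounds:
compound 1, `CCO/N=C/Nc1cc(Cl)c(OCC(C)C)c(Cl)c1`, in a physicochemical assay for lipophilicity, measured as octanol-water partition; a lower number here means a more polar compound, a higher number a more lipophilic compound: 5
compound 2, `C#CCc1c(Cl)cc(N/C=N/OC)cc1Cl`, in this assay: 3.3

Compound 2 stands at the lower of the two numbers in this assay; compound 1 lies higher by a gap that is clearly beyond the usual scatter. The two compounds differ in more than one place, so their values are reported side by side without a single step being assigned between them.

Compound 3, `C#CCc1c(Cl)cc(N/C=N/Oc2ccccc2)cc1Cl`, is not yet measured. It differs from compound 2 in one place: phenyl in place of methyl on an oxygen. Read one bond further out, the change is methoxy to phenoxy.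

For this change the expected step in this assay is an increase well beyond the scatter, a number 1.70 log units higher from compound 2 to compound 3 (beyond the scatter). On that basis compound 3 is estimated at 5, within a range from 4.3 to 5.7.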

Compound 3, partition coefficient: 4.4
Compound 3: the middle estimate sits 0.60 log units above what was measured; the measured number falls inside the stated range.
By their numbers in this assay, from the lowest: compound 2; then compound 3; then compound 1.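

Among these compounds, compound 3 gives the first step that can be tied to one place: with phenyl in place of methyl on an oxygen whose other neighbour is a double-bonded nitrogen, the reading in this assay is a number 1.10 log units higher from compound 2 to compound 3 (beyond the scatter). Compound 1 and compound 2 differ in more than one place, so they could not isolate this position. The step therefore shows that this single change, on the core shared by compound 2 and compound 3, is enough to move the number beyond the scatter, although nothing among the data shown accounts for its size.

Going by these compounds, this remains a single pair on a single core, so it is open whether the step would carry over to another core. Also open, on these data alone, is where a benzyl group, or a longer chain ending in an amine or a carboxylic acid, would fall on this same oxygen.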